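Phenol in place of methoxy on the chloroquinoline amine

This account rests on a few compounds, and the source may have more. Where it says the series, first, only, none or still open, it means among the compounds named here.

Measured so far in a functional assay on PC-3 cells (Homo sapiens) for antiproliferative activity, read by MTT assay, with a stated time of 96 h; on this read-out lower numbers stand for stronger inhibition of growth and higher numbers for weaker inhibition of growth:
compound 1, `COc1ccc(Cl)c2ccc(Nc3ccccn3)nc12`: 29200 nM
compound 2, `COc1ccc(Cl)c2ccc(Nc3cc(C)ccn3)nc12`: > 30000 nM, a limit of this assay rather than a number

Compound 2 thus stands only at the limit of > 30000 nM in this assay, at which 1 of the 2 values shown sits. Going by the values given here, the single measured step, an at least 1.0-fold higher number from compound 1 to compound 2 (0.01 log units; that floor lies within the scatter), lies within the scatter. Compound 3, `Cc1ccnc(Nc2ccc3c(Cl)ccc(O)c3n2)c1`, differs from compound 2 by hydrogen in place of methyl on an oxygen on an aromatic ring. Among the compounds with values here, no measured step touches an oxygen substituent, so the expectation rests on the small change and on compound 2 sitting at the limit. The expected step, a step that the limit leaves unreadable from compound 2 to compound 3, is none beyond the scatter, with a fair chance of another limit. Compound 3 is estimated at 35000 nM, range 12000 nM to 100000 nM.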

Compound 3, concentration for 50% growth inhibition: 10200 nM
Compound 3: middle estimate off by 3.4-fold (0.54 log units), on the high side; the whole stated range lies above it.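

In this assay, going by these compounds alone, methoxy to hydroxy on the aromatic ring gives an at least 2.9-fold lower number from compound 2 to compound 3 (0.46 log units; beyond the scatter), the first step beyond the scatter and the first read at this oxygen. The size of this step is only a floor, because compound 2 stands at a limit: the limit of > 30000 nM in this assay, at which 1 of the 3 values shown sits.

From the compounds shown here alone, whether the free hydroxy itself is what counts at this place stays open. An amine or a longer alkoxy chain on the same aromatic carbon would bear on that, as would a hydroxy on the core of compound 1.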